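Adding a Methyl Group and Membrane Passage

The source may report more compounds than this note shows. Statements on the series, on what has been measured and on what is new or still open speak of the compounds shown alone.

The measured compounds in an ADME assay for permeability, using PAMPA, with a stated time of 4 h, at pH 7.4, tested at 100 uM; on this read-out lower numbers stand for lower permeability and higher numbers for higher permeability:
compound 1, `Cc1nc2cc(-c3ccccc3)nn2c(-c2cc(F)c3c(c2C)CCCO3)c1C(OC(C)(C)C)C(=O)O`: 218 nm/s
compound 2, `Cc1ccc(-c2cc3nc(C)c(C(OC(C)(C)C)C(=O)O)c(-c4cc(F)c5c(c4C)CCCO5)n3n2)cc1`: 492 nm/s
compound 3, `Cc1nc2cc(-c3cccc(-c4ccccc4)c3)nn2c(-c2cc(F)c3c(c2C)CCCO3)c1[C@H](OC(C)(C)C)C(=O)O`: 733 nm/s

Compound 1 and compound 2 share a core and differ in one place only: methyl in place of hydrogen on an aromatic carbon. This change brought a 2.3-fold higher number from compound 1 to compound 2 (0.35 log units; beyond the scatter) in this assay. Compound 3 has a different core from compound 1, and the difference between the two cores is not broken down here; its value stands highest of the three, though the gap to compound 2 lies within the usual scatter, while the gap to compound 1 lies beyond it.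

Compound 4, `Cc1ccccc1-c1cccc(-c2cc3nc(C)c([C@H](OC(C)(C)C)C(=O)O)c(-c4cc(F)c5c(c4C)CCCO5)n3n2)c1`, is not yet measured. It differs from compound 3 by methyl in place of hydrogen on an aromatic carbon. Among the measured compounds shown here, this is the same kind of change as the one from compound 1 to compound 2, but not the same: in compound 2 the methyl sits para to a large group, in compound 4 it sits ortho to a large group.

For the measured compounds named here, since the one earlier example of this kind of change gave a modest rise, compound 4 is expected to show a 1.5-fold higher number from compound 3 to compound 4 (0.18 log units; within the scatter) in this assay, somewhat smaller than the step seen from compound 1 to compound 2 because that step, a 2.3-fold higher number from compound 1 to compound 2 (0.35 log units; beyond the scatter), was made at a different place on the ring. The estimate for compound 4 is 1100 nm/s, expected to fall between 600 nm/s and 2000 nm/s.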

Compound 4, apparent permeability: 471 nm/s
For compound 4 the middle estimate is 2.3-fold (0.37 log units) above the measured one; measured number outside the range, below it.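

In this assay, the change from phenyl to 2-methylphenyl gave a 1.6-fold lower number from compound 3 to compound 4 (0.19 log units; within the scatter), a step too small to tell compound 3 and compound 4 apart. The gain seen on the first core therefore did not reappear on the second, and the two steps differ by more than repeat measurements would explain: the same change on two cores in this assay, a 2.3-fold higher number (0.35 log units; beyond the scatter) from compound 1 to compound 2 and a 1.6-fold lower number (0.19 log units; within the scatter) from compound 3 to compound 4, 3.5-fold (0.55 log units) apart, beyond the scatter of two such steps This does not show that the core alone sets the outcome, since the two pairs also differ in where the methyl sits, with the methyl in compound 4 ortho to a large group, and two pairs are too few to support a rule for the series.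

The compounds shown leave open what a methyl would do at the same place on both cores, which is the comparison needed to separate the effect of the core from the effect of the position. They also leave open whether a different small group at the ortho place in compound 4, such as an ethyl, a methoxy or an amine, would give a step that could be read beyond the scatter.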